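The compounds below may be only part of what the source reports. "The series", "measured", "known", "first", "only" and "open" are said of these compounds alone.

Measured compounds in this series:

compound 1, `COc1c(CC(=O)O)c(C)nn1-c1cccc(NC(=O)[C@H]2C[C@@H]2c2ccccc2)c1`; compound 2, `Cc1c(CC(=O)O)c(-c2ccccc2)nn1Cc1ccc(F)cc1S(=O)(=O)N1CCNCC1`; compound 3, `Cc1c(CC(=O)O)c(-c2ccc(O)nc2)nn1C(c1ccc(F)cc1)c1ccc(F)cc1`; compound 4, `Cc1c(CC(=O)O)c(-c2ccccc2)nn1C(c1ccc(F)cc1)c1ccc(F)cc1`, not yet measured.

In a functional assay on CHO-K1 cells for antagonist activity at prostaglandin D2 receptor 2 (Homo sapiens), read by scintillation counting and GTPgammaS binding, with stated times of 1 h and 2 h (on this read-out higher numbers stand for weaker inhibition and lower numbers for stronger inhibition), compound 1 gives 1600 nM. In this assay compound 2 gives 5000 nM. Going by the values given here, compound 3 stands apart: in this assay compound 3 gives "not active" (no number reported), and no number is attached to it; no step from compound 3 to any other compound can be sized. Compound 4 is derived from compound 3 by a single change on the shared core: phenyl in place of 6-hydroxypyridin-3-yl on an aromatic carbon. Among the compounds with values here, the same phenyl group sits at that place in compound 2, which is the only measured compound bearing it, and compound 2 carries a different group on the ring nitrogen. Compound 3 is without a number; no step size toward compound 4 can be set from it. The expectation rests on compound 2 alone and is weak. For compound 4 a value in the region of compound 2 is expected, with a wide range, estimated at 4000 nM between 800 nM and 20000 nM, and with a real chance that only a limit is returned.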

Compound 4, half-maximal inhibitory concentration: 1100 nM
For compound 4 the middle estimate is 3.6-fold (0.56 log units) above the measured one; low and high end bracket the measured number.
By their numbers in this assay, from the lowest: compounds 4 and 1 (each within the scatter of the next); then compound 2.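

In this assay, going by these compounds alone, compound 3 gives "not active" (no number reported) and compound 4 gives 1100 nM there, so no step between them can be read. The compounds shown leave open how large the change from 6-hydroxypyridin-3-yl to phenyl is on this core. No supporting evidence bears on this result.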